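Swapping the aryl on the hydrazone carbon of compound 2

The source may report more compounds than this note shows. Statements on the series, on what has been measured and on what is new or still open speak of the compounds shown alone.

Of the compounds shown here, three that share one core have been tested in a functional assay on HepG2 cells (Homo sapiens) for inhibition, read by MTT assay, with a stated time of 72 h; a lower number here means a stronger inhibitor, a higher number a weaker inhibitor. Compound 1 `CN(C(=O)NC(=O)c1ccc([N+](=O)[O-])cc1)c1nc(C(F)(F)F)c(C(=O)N/N=C/c2cccc(C(F)(F)F)c2)s1` gives 4.73 ug/mL, compound 3 `CN(C(=O)NC(=O)c1ccccc1F)c1nc(C(F)(F)F)c(C(=O)N/N=C/c2cccc(C(F)(F)F)c2)s1` gives 20.3 ug/mL, and compound 2 `COc1ccc(/C=N/NC(=O)c2sc(N(C)C(=O)NC(=O)c3c(F)cccc3F)nc2C)cc1` gives 22.7 ug/mL, the highest of the three numbers. Compound 2 and compound 3 lie within the scatter of one another, while the step of a 4.3-fold higher number from compound 1 to compound 3 (0.63 log units; beyond the scatter) is a modest one and concerns the aryl on the carbonyl carbon, not the position changed here.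

Compound 4 `Cc1nc(N(C)C(=O)NC(=O)c2c(F)cccc2F)sc1C(=O)N/N=C/c1cccc(C(F)(F)F)c1` differs from compound 2 in one place: 3-(trifluoromethyl)phenyl in place of 4-methoxyphenyl on a carbon with a double bond to nitrogen. Within the data shown here, no measured pair shows this exact change. Compound 1 and compound 3 both already carry the 3-(trifluoromethyl)phenyl group at that position, and compound 3 sits within the scatter of compound 2, but those two differ in more than one place, so this is only weak guidance. The step of a 1.3-fold lower number from compound 2 to compound 4 (0.10 log units; within the scatter) is therefore expected to stay within the scatter, and compound 4 is estimated at 18 ug/mL, with a range from 8 ug/mL to 45 ug/mL.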

Compound 4, half-maximal inhibitory concentration: 31.6 ug/mL
Estimate against measurement, compound 4: 1.8-fold (0.24 log units) below; low and high end bracket the measured number.
By their numbers in this assay, from the lowest: compound 1; then compounds 3, 2 and 4 (each within the scatter of the next).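

Among these compounds, the pair gives the first direct reading at this position in this assay: a 1.4-fold higher number from compound 2 to compound 4 (0.14 log units; within the scatter). On a carbon with a double bond to nitrogen, then, 3-(trifluoromethyl)phenyl and 4-methoxyphenyl cannot be told apart in this assay, even though the oxygen of one group gives way to the fluorine atoms of the other. Nothing available bears on why this is so.

Going by these compounds, this reading comes from a single pair, so it remains open whether the same change would stay within the scatter in compounds carrying 4-nitrophenyl on the carbonyl carbon. On these data alone, it is also open whether an amine or a carboxylic acid on that aryl ring, or a longer chain in place of the ring, would give a step beyond the scatter.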